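Removing the Trifluoromethyl Group from Compound 2

A few compounds are considered here, and "the series" means these few. Any claim that something is new, unique, unknown or untested is made for them only; others in the source may bear on it.

Compound 1 `Nc1cccc(-c2cccc(NC(=O)C(Cl)Cl)c2)c1`: > 50000 nM (a limit of the assay)
Compound 2 `O=C(Nc1cccc(-c2ccc(C(F)(F)F)cc2)c1)C(Cl)Cl`: 33600 nM

Within the data shown here, in a functional assay on NCI-H460 cells (Homo sapiens) for cytotoxicity, read by MTT assay, with a stated time of 68 h (a lower number here means a stronger inhibitor, a higher number a weaker inhibitor), compound 2 gives 33600 nM, the only actual number so far. Compound 1 reaches only a limit of the assay, > 50000 nM.

Compound 3 `O=C(Nc1cccc(-c2ccccc2)c1)C(Cl)Cl` is compound 2 with a single change: hydrogen in place of trifluoromethyl on an aromatic carbon. This puts hydrogen in place of trifluoromethyl on an aromatic carbon, para to a large group. Among the measured compounds shown here, no measured pair shows this change, so the expectation is tentative: a small move toward weaker inhibition, possibly none beyond the scatter. For compound 2, little room remains because 33600 nM already marks weak inhibition. Compound 3 could also return only a limit rather than a number. The expected change is a 1.2-fold higher number from compound 2 to compound 3 (0.08 log units; within the scatter). Compound 3 is expected at 40000 nM, with an estimated range of 18000 nM to 80000 nM.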

Compound 3, half-maximal inhibitory concentration: 20200 nM
The estimate for compound 3 lay 2.0-fold (0.30 log units) above the measured number; the measured number falls inside the stated range.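

In this assay, among these compounds, the step of a 1.7-fold lower number from compound 2 to compound 3 (0.22 log units; within the scatter) is the first measured comparison for trifluoromethyl on this aromatic carbon. It lies within the scatter, so hydrogen and trifluoromethyl at this place cannot be told apart in these data. Putting hydrogen in place of amino on an aromatic carbon gives a clearer result, an at least 2.4-fold lower number from compound 1 to compound 3 (0.39 log units; beyond the scatter), which lies beyond the scatter, although compound 1 stands at a limit of the assay and not at a number, so this step gives only a minimum size: the limit of > 50000 nM in this assay, at which 1 of the 3 values shown sits.

As far as these compounds go, whether a carboxylic acid or a methoxy group on the same carbon would move the number beyond the scatter from that of compound 3 remains open. From the compounds shown here alone, the true distance between compound 1 and compound 3 also stays unknown.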